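A 2-Chlorophenyl Variant of Compound 1 Awaiting Measurement

This account rests on a few compounds, and the source may have more. Where it says the series, first, only, none or still open, it means among the compounds named here.

Measured compounds:
compound 1 `CCN1CCN(c2cc(C)c3cc(NC(=O)c4ccc(C)cc4)ccc3n2)CC1` — 6740 nM
compound 2 `CCN1CCN(c2cc(C)c3cc(NC(=O)c4cc(Cl)cc(Cl)c4)ccc3n2)CC1` — 6090 nM
compound 3 `Cc1cc(NCCN2CCCC2)nc2ccc(NC(=O)c3ccc(Cl)c(Cl)c3)cc12` — 1280 nM

In a functional assay on MCF7 cells (Homo sapiens) for antiproliferative activity, read by MTT assay, with a stated time of 72 h (on this read-out lower numbers stand for stronger inhibition and higher numbers for weaker inhibition), compound 1 gives the highest of the three numbers. Compound 2 stands nearest to it, with a 1.1-fold lower number from compound 1 to compound 2 (0.04 log units; within the scatter). Compound 3, which differs from compound 1 in more than one place, gives the lowest value of the three.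

Compound 4 `CCN1CCN(c2cc(C)c3cc(NC(=O)c4ccccc4Cl)ccc3n2)CC1` has not yet been measured. It differs from compound 1 in one place: 2-chlorophenyl in place of 4-methylphenyl on a carbonyl carbon. Within the data shown here, the only measured step that bears on this change is the exchange of the aryl group on the same carbonyl carbon, from compound 1 to compound 2, which stayed within the scatter. No step beyond the scatter is therefore expected in this assay for compound 4, an expected 1.1-fold lower number from compound 1 to compound 4 (0.05 log units; within the scatter). Compound 4 is estimated to give 6000 nM in this assay, with a range from 2500 nM to 14000 nM.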

Compound 4, half-maximal inhibitory concentration: > 50000 nM
Compound 4: only a limit was reported; the forecaster's own chance of this, stated with the estimate: 5%; at least 8.3-fold (0.92 log units) between middle value and limit.
By their numbers in this assay, from the lowest: compound 3; then compounds 2 and 1 (each within the scatter of the next). At a limit, above all of these: compound 4.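

In this assay the value of compound 4 is a limit and not a number: the limit of > 50000 nM in this assay, at which 1 of the 4 values shown sits. This position therefore does not tolerate every aryl group: the exchange to 3,5-dichlorophenyl gave a 1.1-fold lower number from compound 1 to compound 2 (0.04 log units; within the scatter), whereas 2-chlorophenyl gives an at least 7.4-fold higher number from compound 1 to compound 4 (0.87 log units; beyond the scatter). Set against the 3,5-dichlorophenyl group, the same change gives an at least 8.2-fold higher number from compound 2 to compound 4 (0.91 log units; beyond the scatter).

Going by these compounds, whether 2-methylphenyl or 4-chlorophenyl on this carbonyl carbon would follow 2-chlorophenyl or 4-methylphenyl stays open. Also open, on these data alone, is whether 2-chlorophenyl would have the same effect with the 2-(pyrrolidinyl)ethylamino chain of compound 3 on the shared core.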